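Series notes: positional isomer of compound 1

This account rests on a few compounds, and the source may have more. Where it says the series, first, only, none or still open, it means among the compounds named here.

Measured so far:
- compound 1 `Cc1ccc(Nc2ncc(C(F)(F)F)c(N3Cc4cccc(N(C)S(C)(=O)=O)c4C3)n2)c(Cl)c1`: in an assay on Sf9 cells for inhibition of tyrosine-protein kinase receptor UFO (Homo sapiens), read by luminescence and ADP-Glo (on this read-out lower numbers stand for stronger inhibition and higher numbers for weaker inhibition), compound 1 gives > 20000 nM, which is a limit of the assay.
- compound 2 `CN(c1cccc2c1CN(c1nc(Nc3ccc(Nc4ccccc4)cc3)ncc1C(F)(F)F)C2)S(C)(=O)=O`: compound 2 gives > 20000 nM, a limit of the assay.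
- compound 3 `CN(c1cccc2c1CN(c1nc(Nc3cc(C(F)(F)F)cc(C(F)(F)F)c3)ncc1C(F)(F)F)C2)S(C)(=O)=O`: compound 3 gives > 20000 nM, a limit of the assay.

Within the data shown here, compound 1 therefore stands at the limit, and so do the two other values shown (the limit of > 20000 nM in this assay, at which 3 of the 3 values shown sit); no step between measured compounds can be sized from these data.

Compound 4 `Cc1cc(Cl)ccc1Nc1ncc(C(F)(F)F)c(N2Cc3cccc(N(C)S(C)(=O)=O)c3C2)n1` differs from compound 1 by 4-chloro-2-methylphenyl in place of 2-chloro-4-methylphenyl on a nitrogen on an aromatic ring; the two have the same atoms, joined differently. Among the measured compounds shown here, with every value at the limit and no measured step to lean on, the step that the limit leaves unreadable from compound 1 to compound 4 is expected to be none beyond the scatter in this assay. Compound 4 is expected to give about 25000 nM, within a range from 8000 nM to 80000 nM, most probably again reported only as a limit.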

Compound 4, half-maximal inhibitory concentration: > 20000 nM
Compound 4: no number, only a limit (the forecaster's own chance of this, stated with the estimate: 85%); the middle value lies beyond the limit too.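

No step can be read from compound 1 to compound 4, since 4-chloro-2-methylphenyl in place of 2-chloro-4-methylphenyl leaves both compounds at a limit: the limit of > 20000 nM in this assay, at which 4 of the 4 values shown sit.

The compounds shown leave open whether any change to the shared core gives a measurable number in this assay.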